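The source may report more compounds than this note shows. Statements on the series, on what has been measured and on what is new or still open speak of the compounds shown alone.

Compound 3 `CC(=O)SCC(=O)c1ccc(NS(=O)(=O)c2ccc(OCCCN3CCCCC3)cc2)nc1` is one of three close relatives that share a common core and differ only in the group attached to an oxygen on an aromatic ring. In a functional assay on HCT-116 cells (Homo sapiens) for cytotoxicity (a lower number here means that less compound is needed, a higher number that more compound is needed for the effect), compound 3 gives 1000 nM, the second highest of the three numbers. Its nearest neighbour is compound 1 `CC(=O)SCC(=O)c1ccc(NS(=O)(=O)c2ccc(OCCc3ccccn3)cc2)nc1`, which gives 750 nM; the step is a 1.3-fold higher number from compound 1 to compound 3 (0.12 log units; within the scatter). Furthest away is compound 2 `CC(=O)SCC(=O)c1ccc(NS(=O)(=O)c2ccc(OCCCO)cc2)nc1`, which gives 8600 nM; the step is an 8.6-fold lower number from compound 2 to compound 3 (0.93 log units; beyond the scatter).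

Compound 4 `CC(=O)SCC(=O)c1ccc(NS(=O)(=O)c2ccc(OC3CCN(C)CC3)cc2)nc1` carries 1-methylpiperidin-4-yl in place of 3-(piperidin-1-yl)propyl on an oxygen on an aromatic ring. Going by the values given here, two measured steps bear on this change. The step of an 8.6-fold lower number from compound 2 to compound 3 (0.93 log units; beyond the scatter) shows a modest gain when a hydroxy group gives way to a piperidin-1-yl group, while a 1.3-fold higher number from compound 1 to compound 3 (0.12 log units; within the scatter) shows that swapping one nitrogen-containing group for another barely moves the number. The incoming group keeps one hydrogen-bond acceptor and no donor, as does the group it replaces, so the expected step is a 1.2-fold higher number from compound 3 to compound 4 (0.08 log units; within the scatter), with no direction beyond the scatter. Compound 4 is therefore expected to give about 1200 nM in this assay, within a range of 450 nM to 3500 nM.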

Compound 4, half-maximal effective concentration: 180 nM
Compound 4: the middle estimate sits 6.7-fold (0.82 log units) above what was measured; measured number outside the range, below it.
By their numbers in this assay, from the lowest: compound 4; then compounds 1 and 3 (each within the scatter of the next); then compound 2.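

In this assay the step of a 5.6-fold lower number from compound 3 to compound 4 (0.74 log units; beyond the scatter) and the step of a 4.2-fold lower number from compound 1 to compound 4 (0.62 log units; beyond the scatter) show that this oxygen substituent can still shift the number well beyond the scatter, even though compounds 1 and 3 sit within the scatter of each other. The 1-methylpiperidin-4-yl group has the same kind of ring and the same hydrogen-bond donor and acceptor counts as the 3-(piperidin-1-yl)propyl group it replaces, so those shared features do not settle the number. The step of a 48-fold lower number from compound 2 to compound 4 (1.68 log units; beyond the scatter) is the largest among these compounds and widens the gap to the 3-hydroxypropyl compound.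

A piperidin-4-yl group without the methyl, or a morpholin-4-yl group on a propyl chain, could help separate the contributions of the methyl, the ring and the chain. No evidence on the reason for this change is at hand.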